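Oxazolidinone EP4 series: trifluoromethyl on the terminal phenyl

The source may hold more compounds than are shown below. What is called first, only, known or untested is meant among the compounds shown, and "the series" means these compounds.

Measured so far:
compound 1 `O=C(O)CCCSCCN1C(=O)OC[C@@H]1/C=C/[C@@H](O)Cc1ccccc1` — 4.2 nM
compound 2 `CCCc1cccc(C[C@H](O)/C=C/[C@H]2CCC(=S)N2CCCCCCC(=O)O)c1` — 0.4 nM

Two compounds of this series carry a value in an assay on CHO cells for displacement of a labelled ligand from prostaglandin E2 receptor EP4 subtype (Mus musculus), read by scintillation counting, with a stated time of 60 min; a lower number here means a stronger inhibitor, a higher number a weaker inhibitor. Compound 1 `O=C(O)CCCSCCN1C(=O)OC[C@@H]1/C=C/[C@@H](O)Cc1ccccc1` gives 4.2 nM and holds the highest of the two numbers. Compound 2 `CCCc1cccc(C[C@H](O)/C=C/[C@H]2CCC(=S)N2CCCCCCC(=O)O)c1` differs from compound 1 in the core, the acid-bearing chain and the substituent on the terminal ring, and compound 2 gives 0.4 nM; the gap between the two lies beyond the scatter, but as the structures differ in several places no single step can be read from it.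

Compound 3 `O=C(O)CCCSCCN1C(=O)OC[C@@H]1/C=C/[C@@H](O)Cc1cccc(C(F)(F)F)c1` keeps the core of compound 1 and changes only the terminal ring: trifluoromethyl in place of hydrogen on an aromatic carbon. Within the data shown here, no measured pair shows this change on its own. Given that compound 2 with a substituted terminal ring gives 0.4 nM, a moderate gain beyond the scatter is expected, a 1.7-fold lower number from compound 1 to compound 3 (0.23 log units; within the scatter). Compound 3 is estimated at 2.5 nM in this assay, within 0.8 nM to 8 nM.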

Compound 3, inhibition constant: 2 nM
Beside the measured number, compound 3's estimate is 1.3-fold (0.10 log units) above it, within the range that was stated.
By their numbers in this assay, from the lowest: compound 2; then compound 3; then compound 1.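

In this assay, among these compounds, trifluoromethyl in place of hydrogen on an aromatic carbon gives a 2.1-fold lower number from compound 1 to compound 3 (0.32 log units; beyond the scatter) and is the first change that can be read on its own, since the rest of the structure of compound 1 stays the same. The terminal phenyl therefore tolerates this group of four heavy atoms on a carbon meta to a large group, with a modest gain that lies beyond the scatter. No measurement available here bears on the reason for this step.

Open, from the compounds shown here alone, is whether the gain belongs to trifluoromethyl itself or would also appear with a chlorine atom, a methoxy group or a nitrile on the same carbon. Also open, going by these compounds, is whether trifluoromethyl on another carbon of the ring, or on a different core, would give a step of similar size.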